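Swapping the aryl group on a urea: compound 2 to compound 3

The source may report more compounds than this note shows. Statements on the series, on what has been measured and on what is new or still open speak of the compounds shown alone.

Among the compounds with values here, compound 2 `COc1cc(Cl)cc(-c2nn(-c3cccc(NC(=O)Nc4ccc(Cl)c(Cl)c4)c3)cc2-c2ccncc2)c1` is, on the numbers so far, the stronger of two measured compounds: in a functional assay on NCI-H522 cells (Homo sapiens) for inhibition, read by sulforhodamine B assay, with a stated time of 48 h, tested at 10 uM (on this read-out higher numbers stand for a weaker effect at the one concentration tested and lower numbers for a stronger effect), compound 2 gives -19%, whereas compound 1 `COc1cc(Cl)cc(-c2nn(-c3cccc(NC(=O)c4ccc(Cl)c(Cl)c4)c3)cc2-c2ccncc2)c1` gives 53.7%. Within the data shown here, the one measured step, a number 72.7 percentage points lower from compound 1 to compound 2 (beyond the scatter), concerns a different place in the molecule, the carbonyl carbon, and says nothing directly about the aryl ring at the far end of the urea. Compound 3 `COc1cc(Cl)cc(-c2nn(-c3cccc(NC(=O)Nc4cccc(C(F)(F)F)c4)c3)cc2-c2ccncc2)c1` differs from compound 2 only there: 3-(trifluoromethyl)phenyl in place of 3,4-dichlorophenyl on an amide-type nitrogen. Among the measured compounds shown here, no measured step touches this ring, so its effect has to be guessed from the fact that both groups are similar-sized aromatic rings carrying halogen-type substituents. The step is therefore expected to be small, and compound 3 is expected to come out a little weaker than compound 2, with an estimated step of a number 19 percentage points higher from compound 2 to compound 3 (beyond the scatter). The estimate for compound 3 is 0%, with a range from -35% to 40%.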

Compound 3, a percentage reported as activity, at one concentration (the size of the read-out at that concentration, not a potency): -18.6%
Compound 3: the middle estimate sits 18.6 percentage points above what was measured; the measured number falls inside the stated range.
By their numbers in this assay, from the lowest: compounds 2 and 3 (each within the scatter of the next); then compound 1.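

In this assay, the urea's outer ring can be changed from 3,4-dichlorophenyl to 3-(trifluoromethyl)phenyl, with 10 heavy atoms in place of 8, and the result is a number 0.4 percentage points higher from compound 2 to compound 3 (within the scatter), so the two rings cannot be told apart in this read-out. The urea compounds also stay well separated from the amide compound with the new ring in place, as shown by a number 72.3 percentage points lower from compound 1 to compound 3 (beyond the scatter); this step changes the ring as well as adding the urea nitrogen, but it shows that the large difference seen earlier does not depend on keeping the 3,4-dichlorophenyl ring. Nothing available explains why these two rings give such similar readings.

As far as these compounds go, both rings on the urea carry chlorine or fluorine, so it remains open whether an unsubstituted phenyl ring, or a phenyl ring bearing an amine or a carboxylic acid, would read the same way. From the compounds shown here alone, it is equally open whether a benzyl group or a simple alkyl chain could replace the aromatic ring on this amide-type nitrogen.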